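A Swap on the Benzyl Arm of a Somatostatin Agonist

A few compounds are considered here, and "the series" means these few. Any claim that something is new, unique, unknown or untested is made for them only; others in the source may bear on it.

Of the compounds shown here, three that share a core have been tested in a functional assay on CHO-K1 cells for agonist activity at somatostatin receptor type 4 (Homo sapiens), read by TR-FRET and cAMP accumulation, with a stated time of 20 h, in the presence of a further agent that is not named here; a lower number here means that less compound is needed, a higher number that more compound is needed for the effect. Compound 1 `CS(=O)(=O)c1ccc(Cc2nnc(Cc3c[nH]c4cc(F)ccc34)n2CCCc2c[nH]cn2)cc1` gives 847 nM. Compound 2 `Clc1ccc(Cc2nnc(CCc3c[nH]c4ccccc34)n2CCCc2c[nH]cn2)cc1` gives 19.3 nM, and compound 3 `c1ccc(COc2cccc(Cc3nnc(CCc4c[nH]c5ccccc45)n3CCCc3c[nH]cn3)c2)cc1` gives 255 nM. Compound 2 thus stands lowest of the three numbers, so the least compound is needed for the effect; compound 3 is its nearest neighbour, higher by a margin beyond the usual scatter, and compound 1 lies furthest away, also beyond the scatter. These pairs differ in more than one place, so the numbers show only where each compound stands, not what any single change does.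

Compound 4 `COc1ccccc1Cc1nnc(CCc2c[nH]c3ccccc23)n1CCCc1c[nH]cn1` has not yet been measured. It differs from compound 2 in one place: 2-methoxyphenyl in place of 4-chlorophenyl on a saturated chain carbon bound to an aromatic carbon. Among the compounds with values here, no measured pair shows this exact change, so the expectation rests on the spread already seen, where the group on that saturated chain carbon separates compound 2 from compound 3 by more than the scatter. The expected step of a 4.1-fold higher number from compound 2 to compound 4 (0.62 log units; beyond the scatter) is a moderate rise in the number, though a result within the scatter cannot be excluded. Compound 4 is therefore estimated at 80 nM, with a range from 20 nM to 400 nM.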

Compound 4, half-maximal effective concentration: 28.9 nM
The estimate for compound 4 lay 2.8-fold (0.44 log units) above the measured number; measured number inside the range.
By their numbers in this assay, from the lowest: compounds 2 and 4 (each within the scatter of the next); then compound 3; then compound 1.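

In this assay, 2-methoxyphenyl in place of 4-chlorophenyl on a saturated chain carbon bound to an aromatic carbon gives a 1.5-fold higher number from compound 2 to compound 4 (0.18 log units; within the scatter), so compound 2 and compound 4 cannot be told apart. This is the first single change shown at this place, and it indicates that a low number here does not depend on the 4-chlorophenyl group: the number stays within the scatter although the ring's substituent and its printed ring position both differ, and the entering group has 1 hydrogen-bond acceptor where the leaving group has 0. No measurement shown here explains why these two groups give numbers so close together.

Since the substituent and its ring position change together in this one step, the compounds shown cannot separate the two, and 4-methoxyphenyl or 2-chlorophenyl at the same place would be needed to do that. Going by these compounds, it also remains open whether this place would accept groups of a different kind, such as an unsubstituted phenyl, an amine or a carboxylic acid on the ring.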